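Compound 3: ethylamino in place of carbamoylmethoxy

The source may report more compounds than this note shows. Statements on the series, on what has been measured and on what is new or still open speak of the compounds shown alone.

Compound 1 `CCNC(=O)c1noc(-c2cc(C(C)C)c(O)cc2O)c1-c1cc(COCC(=O)O)no1` and compound 2 `CCNC(=O)c1noc(-c2cc(C(C)C)c(O)cc2O)c1-c1cc(COCC(N)=O)no1` share one core and differ in a side chain. In a functional assay on HCT-116 cells (Homo sapiens) for inhibition (on this read-out higher numbers stand for weaker inhibition and lower numbers for stronger inhibition), compound 1 gives "not determined" (no result reported) and so offers no number for comparison. In this assay, within the data shown here, compound 2 gives 97 nM as the only number so far, so its standing cannot be ranked against any other compound.

The next compound to be read is compound 3 `CCNCc1cc(-c2c(C(=O)NCC)noc2-c2cc(C(C)C)c(O)cc2O)on1`, which carries ethylamino in place of carbamoylmethoxy on a saturated chain carbon bound to an aromatic carbon. Among the measured compounds shown here, no measured step speaks to this change, so the expectation is loose and rests only on compound 2 at 97 nM as the single reference. A shift no larger than the usual scatter is expected, if anything toward stronger inhibition. The estimated step of a 1.6-fold lower number from compound 2 to compound 3 (0.21 log units; within the scatter) is therefore small, with a wide margin on either side. In this assay the expected value for compound 3 is 60 nM within an estimated range of 15 nM to 240 nM for a single measurement.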

Compound 3, half-maximal inhibitory concentration: 45 nM
Compound 3: the middle estimate sits 1.3-fold (0.12 log units) above what was measured; low and high end bracket the measured number.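

In this assay, among these compounds, the replacement of carbamoylmethoxy by ethylamino on a saturated chain carbon bound to an aromatic carbon gives a 2.2-fold lower number from compound 2 to compound 3 (0.33 log units; beyond the scatter) and is the first measured step, showing that the side chain at this position can alter the read-out. The step is modest but lies beyond the usual scatter, and it runs toward stronger inhibition even though the group that enters has 3 heavy atoms against the 5 of the group that leaves and lacks its double bond outside aromatic rings. No evidence is available that accounts for this step.

Compound 1 gives "not determined" (no result reported) and so adds no second comparison at this position, which leaves a single step to describe the side chain. Open questions are whether a methylamino or propylamino group, a tertiary amine such as dimethylamino, or a ring amine such as morpholine would hold the lower number in this assay and whether an ether such as ethoxy at the same place would do the same as ethylamino.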